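Dicarboxy groups on the amide nitrogen of the shared core

The compounds below may be only part of what the source reports. "The series", "measured", "known", "first", "only" and "open" are said of these compounds alone.

The series shares the core of compound 1 `CCn1c(C(=O)NCC(=O)OC)ccc1C(CC)(CC)c1ccc(OCS(=O)(=O)c2ccccc2)c(C)c1` and varies the group on an amide-type nitrogen. In a functional assay on MCF7 cells (Homo sapiens) for antiproliferative activity, read by MTT assay, with a stated time of 24 h (on this read-out lower numbers stand for stronger inhibition and higher numbers for weaker inhibition), compound 1 gives a limit of the assay, > 50000 nM. Within the data shown here, compound 2 `CCn1c(C(=O)N[C@@H](CO)C(C)C)ccc1C(CC)(CC)c1ccc(OCS(=O)(=O)c2ccccc2)c(C)c1` carries a 1-(hydroxymethyl)-2-methylpropyl there, and in this assay compound 2 gives 18800 nM, the only number on hand. Compound 3 `CCn1c(C(=O)N[C@H](CC(=O)O)C(=O)O)ccc1C(CC)(CC)c1ccc(OCS(=O)(=O)c2ccccc2)c(C)c1` carries a 1,2-dicarboxyethyl, and in this assay compound 3 gives a limit of the assay, > 50000 nM. The measured steps run an at least 2.6-fold lower number from compound 1 to compound 2 (0.42 log units; beyond the scatter) and an at least 2.6-fold higher number from compound 2 to compound 3 (0.42 log units; beyond the scatter), while the pair a step that the two limits leave unreadable from compound 1 to compound 3.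

Compound 4 `CCn1c(C(=O)N[C@@H](CCC(=O)O)C(=O)O)ccc1C(CC)(CC)c1ccc(OCS(=O)(=O)c2ccccc2)c(C)c1` is not yet measured. Against compound 2 it shows (1,3-dicarboxypropyl in place of 1-(hydroxymethyl)-2-methylpropyl on an amide-type nitrogen). Among the measured compounds shown here, the step from compound 2 to compound 3 is the closest precedent, a dicarboxy chain in place of the same hydroxymethyl group on the same nitrogen, and it raised the number beyond the scatter. A step of similar size toward a higher number is therefore expected in this assay, a 3.2-fold higher number from compound 2 to compound 4 (0.50 log units; beyond the scatter). Compound 4 is estimated at 60000 nM in this assay, within a range from 25000 nM to 150000 nM, and most likely reported only as a limit.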

Compound 4, half-maximal inhibitory concentration: > 50000 nM
Compound 4: only a limit was reported (the forecaster's own chance of this, stated with the estimate: 70%); the middle value lies beyond the limit too.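

Replacing the 1-(hydroxymethyl)-2-methylpropyl with 1,3-dicarboxypropyl on this amide-type nitrogen gives an at least 2.6-fold higher number from compound 2 to compound 4 (0.42 log units; beyond the scatter) in this assay, so a second dicarboxy chain moves the result the same way as the 1,2-dicarboxyethyl of compound 3. The longer dicarboxy chain brings no readable number at this position, and the steps to compound 4 from compound 1 and from compound 3 cannot be read, as both ends of each are limits. Compound 2 stays the only compound with a number, and any difference among the other three is hidden: the limit of > 50000 nM in this assay, at which 3 of the 4 values shown sit.

Open, from the compounds shown here alone, is whether a single carboxylic acid, a dimethyl ester of the 1,3-dicarboxypropyl or an amine on this nitrogen would give a number inside the assay's range. Also open, going by these compounds, is whether the hydroxymethyl or the branched isopropyl part of compound 2 goes with its readable value.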